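The compounds below may be only part of what the source reports. "The series", "measured", "known", "first", "only" and "open" are said of these compounds alone.

Compound 2, with the structure `COc1ccc(-c2cn(C[C@H](O)[C@H]3OC(=O)C(OCc4ccccc4)=C3OCc3ccccc3)nn2)cc1`, sits at the sensitive end of the numbers available here: in an ADME assay on HFF cells (Homo sapiens) for cytotoxicity, read by MTT assay, with a stated time of 72 h (a higher number here means a weaker inhibitor, a lower number a stronger inhibitor), compound 2 gives < 10 nM, which is a limit of the measurement rather than a number. The other measured compound, compound 1 with the structure `C[Si](C)(C)c1cn(C[C@H](O)[C@H]2OC(=O)C(OCc3ccccc3)=C2OCc2ccccc2)nn1`, gives 20000 nM in this assay. Within the data shown here, the single measured step, an at least 2000-fold lower number from compound 1 to compound 2 (3.30 log units; beyond the scatter), is large, and it rests on (the limit of < 10 nM in this assay, at which 1 of the 2 values shown sits).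

Compound 3, with the structure `COc1ccccc1-c1cn(C[C@H](O)[C@H]2OC(=O)C(OCc3ccccc3)=C2OCc2ccccc2)nn1`, differs from compound 2 by 2-methoxyphenyl in place of 4-methoxyphenyl on an aromatic carbon. The group keeps the same atoms and is rearranged on an aromatic carbon of a five-membered aromatic ring with 3 nitrogen. Among the measured compounds shown here, no measured step speaks to such a rearrangement; the step from compound 1 to compound 2 exchanged a whole group for another, which is a different kind of change, so it gives no direct guide.

For the measured compounds named here, with no comparable step, the expectation is that this assay shows no step beyond the scatter, so that an at least 1.2-fold higher number from compound 2 to compound 3 (0.07 log units; that floor lies within the scatter) is estimated, and compound 3 is expected to give roughly 12 nM, between 3 nM and 60 nM, with a fair chance that the measurement again reports only a limit.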

Compound 3, half-maximal inhibitory concentration: 50 nM
The estimate for compound 3 lay 4.2-fold (0.62 log units) below the measured number; low and high end bracket the measured number.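

Exchanging 4-methoxyphenyl for 2-methoxyphenyl, with the same atoms simply joined differently, gives an at least 5.0-fold higher number from compound 2 to compound 3 (0.69 log units; beyond the scatter) in this assay, so at this aromatic carbon the arrangement of a group changes the reading, and not only which atoms it holds. For compound 2 the reading of < 10 nM is a limit and not a number, so the step can be read only as a minimum and its true size stays unknown: the limit of < 10 nM in this assay, at which 1 of the 3 values shown sits.

The exchange of the silicon-bearing group for a methoxyphenyl group now has a fully numerical measure as well, a 400-fold lower number from compound 1 to compound 3 (2.60 log units; beyond the scatter), which shows that the large drop seen earlier holds for both arrangements of the methoxy group.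

The compounds shown do not separate the part played by the methoxy group from that of the phenyl ring carrying it, a question that a plain phenyl, or a phenyl bearing an amine or a carboxylic acid in place of the methoxy group, would address. Whether the gap between compound 2 and compound 3 would also appear in other cells or over another exposure time also stays open, since this assay is the only assay shown.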